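This account rests on a few compounds, and the source may have more. Where it says the series, first, only, none or still open, it means among the compounds named here.

Three compounds share one core and differ only in the length of a straight saturated chain attached to it. Compound 1 `CCCCC[C@@H]1N[C@@H](CO)[C@H](O)[C@H]1O` carries the shortest chain; in an assay on isolated protein (strain Wistar) for inhibition of lysosomal alpha-glucosidase (Rattus norvegicus), with a stated time of 30 min (on this read-out higher numbers stand for weaker inhibition and lower numbers for stronger inhibition), compound 1 gives 710 nM. Compound 2 `CCCCCCC[C@@H]1N[C@@H](CO)[C@H](O)[C@H]1O` gives 380 nM in this assay, and compound 3 `CCCCCCCCC[C@@H]1N[C@@H](CO)[C@H](O)[C@H]1O` gives 840 nM. Compound 3 has the largest of the three numbers, although its difference from compound 1 is within the scatter, whereas the step from compound 2 to compound 3 is a 2.2-fold higher number from compound 2 to compound 3 (0.34 log units; beyond the scatter).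

Compound 4 `CCCCCCCCCC[C@@H]1N[C@@H](CO)[C@H](O)[C@H]1O` lengthens the chain once more: methyl in place of hydrogen on a saturated chain carbon, nine bonds along the chain from a saturated ring carbon. The earlier chain extensions point in no single direction. Ethyl in place of hydrogen gave a 1.9-fold lower number from compound 1 to compound 2 (0.27 log units; within the scatter), butyl in place of hydrogen gave a 1.2-fold higher number from compound 1 to compound 3 (0.07 log units; within the scatter), and the further ethyl in place of hydrogen gave a 2.2-fold higher number from compound 2 to compound 3 (0.34 log units; beyond the scatter). A methyl in place of hydrogen is a smaller change than any of these, so in this assay no step beyond the scatter is expected, with at most a slight drift toward a higher number, and the expected step is a 1.1-fold higher number from compound 3 to compound 4 (0.05 log units; within the scatter). Compound 4 is therefore estimated at 950 nM in this assay, with a likely range from 450 nM to 2000 nM.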

Compound 4, half-maximal inhibitory concentration: 1200 nM
Beside the measured number, compound 4's estimate is 1.3-fold (0.10 log units) below it, and the stated range covers the measured number.
By their numbers in this assay, from the lowest: compounds 2, 1, 3 and 4 (each within the scatter of the next, the first and the last beyond it).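

In this assay, the methyl added on a saturated chain carbon, nine bonds along the chain from a saturated ring carbon, gives a 1.4-fold higher number from compound 3 to compound 4 (0.15 log units; within the scatter), so at this place the change cannot be told apart from the usual variation between repeats. The wider comparisons say more than this single step: a 3.2-fold higher number from compound 2 to compound 4 (0.50 log units; beyond the scatter) is the largest step among the four compounds and confirms the separation already seen with compound 3, while a 1.7-fold higher number from compound 1 to compound 4 (0.23 log units; within the scatter) means that the shortest chain and the longest chain cannot be separated in this assay, so the numbers do not follow chain length in one steady direction. Nothing available on these compounds explains this behaviour.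

Going by these compounds, whether a longer chain than that of compound 4 would move the number further or leave it where it is remains open. So does the effect of a branched chain, or of a chain bearing a hydroxyl, an amine or a carboxylic acid, since every chain compared here is straight and saturated.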